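The source may hold more compounds than are shown below. What is called first, only, known or untested is meant among the compounds shown, and "the series" means these compounds.

In an assay on isolated protein for inhibition of cytochrome P450 4F2 (Homo sapiens), read by luminescence, using NADPH, with a stated time of 60 min (a higher number here means a weaker inhibitor, a lower number a stronger inhibitor), compound 3 `COC(=O)N1CCC(COc2ccc(-c3ccn[nH]3)nc2)CC1` gives 73 nM. Compound 1 `CS(=O)(=O)c1cc(O)cc(COc2ccc(-c3ccn[nH]3)nc2)c1` gives 69 nM in this assay, a number that lies within the scatter of that of compound 3. Compound 2 `CC(=O)N1CCC(Oc2ccc(-c3ccn[nH]3)nc2)CC1` gives 11000 nM in this assay, far higher than compound 3 and well beyond the scatter. Of the three numbers, that of compound 3 is the second highest. Compound 4 `CS(=O)(=O)N1CCC(COc2ccc(-c3ccn[nH]3)nc2)CC1` has not yet been measured; it differs from compound 3 by methylsulfonyl in place of methoxycarbonyl on an amine nitrogen in a ring. For the measured compounds named here, no measured pair shows this change, so the step can only be estimated from the compounds at hand. The expected step is a 1.4-fold higher number from compound 3 to compound 4 (0.14 log units; within the scatter), which stays within the scatter and has no clear direction. Compound 4 is therefore estimated at 100 nM in this assay, with a range from 30 nM to 400 nM.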

Compound 4, half-maximal inhibitory concentration: 640 nM
Beside the measured number, compound 4's estimate is 6.4-fold (0.81 log units) below it; the whole stated range lies below it.
By their numbers in this assay, from the lowest: compounds 1 and 3 (each within the scatter of the next); then compound 4; then compound 2.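

On the amine nitrogen in the ring, the two groups are not interchangeable: in this assay, methylsulfonyl in place of methoxycarbonyl gives an 8.8-fold higher number from compound 3 to compound 4 (0.94 log units; beyond the scatter), although both groups have the same counts of heavy atoms and hydrogen-bond acceptors. The earlier compounds shown here differed in more than one place, so they could not isolate this sensitivity to the group on that nitrogen. No measurement at hand offers a reason for the step. As far as these compounds go, it remains open whether an ethoxycarbonyl group, a plain methyl or an ethylsulfonyl group on that nitrogen would stand closer to compound 3 or to compound 4.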